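From compound 3 to compound 4: adding a methoxy

This account rests on a few compounds, and the source may have more. Where it says the series, first, only, none or still open, it means among the compounds named here.

Of the compounds shown here, three have been read in a functional assay on A549 cells (Homo sapiens) for cytotoxicity, read by MTT assay, with a stated time of 48 h; a lower number here means a stronger inhibitor, a higher number a weaker inhibitor. Compound 1 `COc1ccc(-c2c[nH]c(=O)n2-c2cc(OC)c(OC)c(OC)c2)cc1N` returns only a limit, > 50000 nM. Compound 2 `COc1ccc(-c2cn(C(=O)Nc3cc(OC)c(OC)c(OC)c3)c(=O)n2-c2cc(OC)c(OC)c(OC)c2)cc1O` also returns only a limit, > 50000 nM. Compound 3 `COc1cc(-n2c(-c3ccccc3)cn(C(C)=O)c2=O)cc(OC)c1OC` likewise returns only a limit, > 50000 nM. Among the measured compounds shown here, no measured pair in the set differs in one place, so no measured step is available as a guide.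

Compound 4 `COc1ccc(-c2cn(C(C)=O)c(=O)n2-c2cc(OC)c(OC)c(OC)c2)cc1` departs from compound 3 by a single change, methoxy in place of hydrogen on an aromatic carbon, para to a large group, which turns phenyl into 4-methoxyphenyl.

The expected step, an at least 1.6-fold lower number from compound 3 to compound 4 (0.22 log units; that floor lies within the scatter), is modest and toward stronger inhibition. This expectation rests only on compound 3 and its two companions, which share (the limit of > 50000 nM in this assay, at which 3 of the 3 values shown sit). A further limit reading in this assay is considered more likely than a number. For compound 4 the estimate is 30000 nM, with an expected range of 5000 nM to 80000 nM.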

Compound 4, half-maximal inhibitory concentration: 17800 nM
Estimate against measurement, compound 4: 1.7-fold (0.23 log units) above, and the stated range covers the measured number.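

In this assay compound 3 gives only a limit, > 50000 nM. Methoxy in place of hydrogen on an aromatic carbon, para to a large group, turning phenyl into 4-methoxyphenyl, gives an at least 2.8-fold lower number from compound 3 to compound 4 (0.44 log units; beyond the scatter), a step beyond the scatter and the first step that can be read in this series. Compound 4 is the only compound shown that gives a number rather than a limit: the limit of > 50000 nM in this assay, at which 3 of the 4 values shown sit.

On these data alone, the full size of the step remains open, as only its floor can be read. Also open, as far as these compounds go, is whether ethoxy or chlorine in the same place would move the number further, and whether methoxy would give a similar step on a core without the acetyl.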